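The source may report more compounds than this note shows. Statements on the series, on what has been measured and on what is new or still open speak of the compounds shown alone.

Compound 1 `CC/C(=C(/c1ccc(/C=C/C(=O)O)cc1)c1cc2ccccc2[nH]1)c1ccccc1C` carries a 2-methylphenyl group on the shared core, and in a functional assay on MCF7 cells (Homo sapiens) for inhibition (a higher number here means a weaker inhibitor, a lower number a stronger inhibitor), compound 1 gives 33 nM. Compound 2 `CC/C(=C(/c1ccc(/C=C/C(=O)O)cc1)c1cc2ccccc2[nH]1)c1ccccc1C(F)(F)F` differs from it by trifluoromethyl in place of methyl on an aromatic carbon, and in this assay compound 2 gives 8 nM; that change produced a 4.1-fold lower number from compound 1 to compound 2 (0.62 log units; beyond the scatter). Compound 3 `CC/C(=C(/c1ccc(/C=C/C(=O)O)cc1)c1cc2ccccc2[nH]1)c1ccc(Cl)c(C)c1` rests on a different core, and its difference from compound 1 is 4-chloro-3-methylphenyl in place of 2-methylphenyl on a double-bonded chain carbon bound to a double-bonded chain carbon and a saturated chain carbon. In this assay compound 3 gives 840 nM, the highest number of the three, with a 25-fold higher number from compound 1 to compound 3 (1.41 log units; beyond the scatter) and a 110-fold higher number from compound 2 to compound 3 (2.02 log units; beyond the scatter).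

Compound 4 `CC/C(=C(/c1ccc(/C=C/C(=O)O)cc1)c1cc2ccccc2[nH]1)c1ccc(Cl)c(C(F)(F)F)c1` has not yet been measured. It differs from compound 3 by trifluoromethyl in place of methyl on an aromatic carbon. Going by the values given here, this is the same kind of change as the one from compound 1 to compound 2, but the surroundings are not the same: in compound 1 the methyl sits on an aromatic carbon ortho to a large group, whereas in compound 3 it sits ortho to a chloro group and meta to a large group. Among the compounds with values here, only one earlier example of this change exists, and it was seen on a different core, so any expectation for compound 4 is loosely founded. In this assay the step expected for compound 4 is a 2.8-fold lower number from compound 3 to compound 4 (0.45 log units; beyond the scatter), somewhat smaller than the earlier one, because a 4.1-fold lower number from compound 1 to compound 2 (0.62 log units; beyond the scatter) was observed where the change sat in different surroundings. Compound 4 is therefore estimated at 300 nM, with a likely range from 100 nM to 1200 nM.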

Compound 4, half-maximal inhibitory concentration: 2200 nM
For compound 4 the middle estimate is 7.3-fold (0.87 log units) below the measured one, and the stated range ends below it.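

In this assay, trifluoromethyl in place of methyl gave a 2.6-fold higher number from compound 3 to compound 4 (0.42 log units; beyond the scatter), and compound 4 also sits well above the other two compounds with the step of a 67-fold higher number from compound 1 to compound 4 (1.82 log units; beyond the scatter) and the step of a 280-fold higher number from compound 2 to compound 4 (2.44 log units; beyond the scatter). Going by these compounds alone, the swap therefore did not carry from one core to the other: the number fell on one core and rose on the other, by a gap larger than repeated measurements would explain: the same change on two cores in this assay, a 4.1-fold lower number (0.62 log units; beyond the scatter) from compound 1 to compound 2 and a 2.6-fold higher number (0.42 log units; beyond the scatter) from compound 3 to compound 4, 11-fold (1.03 log units) apart, beyond the scatter of two such steps With only two pairs, this shows that the effect of the swap depends on its surroundings, but it does not show why the direction reversed, nor whether the chloro group or the place of the swapped group on the ring decides the outcome.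

The compounds shown leave open how other groups in the same spot, such as a nitrile or a methoxy group, would behave on each core. They also leave open whether the reversal would persist if the chloro group of compound 4 were replaced by a fluoro group or removed altogether.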